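This account rests on a few compounds, and the source may have more. Where it says the series, first, only, none or still open, it means among the compounds named here.

Measured in a functional assay on MDA-MB-436 cells (Homo sapiens) for antiproliferative activity, read by MTT assay, with a stated time of 48 h; a higher number here means a weaker inhibitor, a lower number a stronger inhibitor:
- compound 1 `CN1CCN(c2ccc(-c3cc4c(N5CCN(S(=O)(=O)C6CC6)CC5)ncnc4s3)cc2)CC1`: 10600 nM
- compound 2 `CN1CCN(c2ccc(-c3cc4c(N5CCN(C(=O)Nc6ccc(C#N)cc6)CC5)ncnc4s3)cc2)CC1`: 5010 nM
- compound 3 `CN1CCN(c2ccc(-c3cc4c(N5CCN(C(=O)Nc6ccc(OC(F)(F)F)cc6)CC5)ncnc4s3)cc2)CC1`: 6250 nM

Compound 3, at 6250 nM, lies within the scatter of both other values, although those two are separated by a 2.1-fold lower number from compound 1 to compound 2 (0.33 log units; beyond the scatter). Compound 4 `CN1CCN(c2ccc(-c3cc4c(N5CCN(C(=O)Nc6ccc(F)cc6F)CC5)ncnc4s3)cc2)CC1` carries 2,4-difluorophenyl in place of 4-(trifluoromethoxy)phenyl on an amide-type nitrogen. The closest measured change is a 1.2-fold higher number from compound 2 to compound 3 (0.10 log units; within the scatter), trifluoromethoxy in place of cyano on an aromatic carbon. Within the data shown here, the only larger step, a 2.1-fold lower number from compound 1 to compound 2 (0.33 log units; beyond the scatter), replaced the whole cyclopropylsulfonyl group and bears less on this change. No step beyond the scatter is therefore expected in this assay. The estimated change is a 1.1-fold lower number from compound 3 to compound 4 (0.06 log units; within the scatter). Compound 4 is expected at 5500 nM, with an estimated range of 2800 nM to 11000 nM.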

Compound 4, half-maximal inhibitory concentration: 20200 nM
Compound 4: middle estimate off by 3.7-fold (0.56 log units), on the low side; measured number above the stated range.
By their numbers in this assay, from the lowest: compounds 2, 3, 1 and 4 (each within the scatter of the next, the first and the last beyond it).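

In this assay the aryl group on the amide-type nitrogen does matter: 2,4-difluorophenyl gives a 3.2-fold higher number from compound 3 to compound 4 (0.51 log units; beyond the scatter) and also a 4.0-fold higher number from compound 2 to compound 4 (0.61 log units; beyond the scatter) and so goes beyond the scatter, which the exchange of cyano for trifluoromethoxy did not. Against cyclopropylsulfonyl, the (2,4-difluorophenyl)carbamoyl group shows a 1.9-fold higher number from compound 1 to compound 4 (0.28 log units; within the scatter) and so does not repeat a 2.1-fold lower number from compound 1 to compound 2 (0.33 log units; beyond the scatter) for the 4-cyanophenyl version; replacing the sulfonyl group is not enough by itself. Open, from the compounds shown here alone, is whether a single fluorine, or an amine or carboxylic acid on the phenyl ring, would keep the number near that of compound 2. Nothing available accounts for the higher number of compound 4.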